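Hydrazone aryl exchange on a shared triazole thioether core

The compounds below may be only part of what the source reports. "The series", "measured", "known", "first", "only" and "open" are said of these compounds alone.

Three compounds have been measured in a functional assay on HepG2 cells (Homo sapiens) for inhibition, read by MTT assay, with a stated time of 48 h; on this read-out lower numbers stand for stronger inhibition and higher numbers for weaker inhibition:
compound 1 `Clc1ccccc1CSc1nnc(-c2ccncc2)n1-c1ccccc1` gives 15700 nM
compound 2 `Brc1ccc(CSc2nnc(-c3ccncc3)n2-c2ccccc2)cc1` gives 12900 nM
compound 3 `O=C(CSc1nnc(-c2ccncc2)n1-c1ccccc1)N/N=C/c1ccc([N+](=O)[O-])cc1` gives 15900 nM

On these numbers compound 3 sits alongside compound 1 and compound 2; its gaps to both lie within the usual scatter, so none of the three is set apart from the others in this assay. Among the compounds with values here, the only measured step, a 1.2-fold lower number from compound 1 to compound 2 (0.09 log units; within the scatter), concerns a different part of the shared core and is itself within the scatter.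

Compound 4 `O=C(CSc1nnc(-c2ccncc2)n1-c1ccccc1)N/N=C/c1ccc(O)c(O)c1` differs from compound 3 in the hydrazone portion: 3,4-dihydroxyphenyl in place of 4-nitrophenyl on a carbon with a double bond to nitrogen. Within the data shown here, no measured pair touches this carbon with a double bond to nitrogen, so nothing among the data speaks for or against a shift here. Compound 4 is therefore expected to stay close to compound 3, with a step of a 1.1-fold lower number from compound 3 to compound 4 (0.03 log units; within the scatter) not reaching beyond the scatter. The estimate for compound 4 in this assay is 15000 nM, within a range of 5000 nM to 45000 nM.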

Compound 4, half-maximal inhibitory concentration: 16900 nM
Beside the measured number, compound 4's estimate is 1.1-fold (0.05 log units) below it, and the stated range covers the measured number.
By their numbers in this assay, from the lowest: compounds 2, 1, 3 and 4 (each within the scatter of the next).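

Within the data shown here, the exchange of 4-nitrophenyl for 3,4-dihydroxyphenyl on a carbon with a double bond to nitrogen gives the only measured step at this place, and in this assay it reads a 1.1-fold higher number from compound 3 to compound 4 (0.03 log units; within the scatter) on the hydrazone portion. The entering group has 2 hydrogen-bond donors where the leaving group has 0, and each has 2 hydrogen-bond acceptors, yet this difference in the groups comes with no separation of the two compounds on this read-out. Nothing available bears on why this is so.

The two aryl groups shown here say nothing about how far this place tolerates other kinds of group. Going by these compounds, whether an amine, a carboxylic acid or a longer chain on this carbon would give a step beyond the scatter stays open.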